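A few compounds are considered here, and "the series" means these few. Any claim that something is new, unique, unknown or untested is made for them only; others in the source may bear on it.

Compound 1, `CCCCCCCCCCCCCCNC(=O)[C@@H](NC(=O)c1cccs1)[C@@H](C)O`, gives 36100 nM in a functional assay on MCF7 cells (Homo sapiens) for cytotoxicity, read by MTT assay, with a stated time of 48 h; a higher number here means a weaker inhibitor, a lower number a stronger inhibitor.
Compound 2, `CCCCCCCCCCCCCCNC(=O)[C@@H](NC(=O)c1cc2ccccc2[nH]1)[C@@H](C)O`, gives 15100 nM in this assay.
Compound 3, `CCCCCCCCCCCCCCNC(=O)[C@@H](NC(=O)/C=C/c1ccccc1)[C@@H](C)O`, gives 64600 nM in this assay.

The three measured compounds share one core and differ only in the group that sits on the carbonyl carbon attached to the amine nitrogen. Compound 3 stands at the highest number of the three; the nearest is compound 1, separated by a 1.8-fold higher number from compound 1 to compound 3 (0.25 log units; within the scatter), and the furthest is compound 2, separated by a 4.3-fold higher number from compound 2 to compound 3 (0.63 log units; beyond the scatter).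

Compound 4, `CCCCCCCCCCCCCCNC(=O)[C@@H](NS(=O)(=O)c1ccc(C)cc1)[C@@H](C)O`, is not yet measured. It departs from compound 3 as follows: (4-methylphenyl)sulfonyl in place of (2-phenylethenyl)carbonyl on an amine nitrogen.

All three measured steps exchange one group for another on the carbonyl carbon, and their sizes were a 2.4-fold lower number from compound 1 to compound 2 (0.38 log units; beyond the scatter), a 1.8-fold higher number from compound 1 to compound 3 (0.25 log units; within the scatter) and a 4.3-fold higher number from compound 2 to compound 3 (0.63 log units; beyond the scatter). Within the data shown here, the change to compound 4 is of a different kind, since the carbonyl itself gives way to a sulfonyl, so no measured step covers it directly. The measured steps suggest that swapping the group on the amine nitrogen moves the number by a modest amount at most. For compound 4 a step of a 1.4-fold lower number from compound 3 to compound 4 (0.16 log units; within the scatter) is therefore expected, which lies within the scatter. Compound 4 is estimated at 45000 nM in this assay, with a range from 14000 nM to 140000 nM.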

Compound 4, half-maximal inhibitory concentration: 12900 nM
The estimate for compound 4 lay 3.5-fold (0.54 log units) above the measured number, and the stated range ends above it.
By their numbers in this assay, from the lowest: compounds 4 and 2 (each within the scatter of the next); then compounds 1 and 3 (each within the scatter of the next).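

In this assay, among these compounds, the amine nitrogen can carry a sulfonyl as well as a carbonyl, something the earlier compounds, which varied only the group on a carbonyl, could not show, and the exchange of (2-phenylethenyl)carbonyl for (4-methylphenyl)sulfonyl gives a 5.0-fold lower number from compound 3 to compound 4 (0.70 log units; beyond the scatter). The sulfonyl compound also differs clearly from the thiophene amide, with a 2.8-fold lower number from compound 1 to compound 4 (0.45 log units; beyond the scatter), but it cannot be told apart from the indole amide, with a 1.2-fold lower number from compound 2 to compound 4 (0.07 log units; within the scatter), so this change matches the best carbonyl result shown here without going past it. No measured evidence accounts for these differences in number.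

The change to compound 4 replaces the carbonyl link and the group attached to it at the same time, so the compounds shown leave open how much of the step belongs to the sulfonyl and how much to the 4-methylphenyl ring. A 4-methylbenzoyl group on the same nitrogen would help separate the two, while a methylsulfonyl group would test whether the aromatic ring is needed on the sulfonyl at all.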